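Changing the Amide Side Chain of Compound 1

A few compounds are considered here, and "the series" means these few. Any claim that something is new, unique, unknown or untested is made for them only; others in the source may bear on it.

In a physicochemical assay for lipophilicity, measured as octanol-water partition, at pH 7.4 (on this read-out higher numbers stand for higher lipophilicity and lower numbers for lower lipophilicity), compound 1 `Cc1ccc2[nH]c(C(=O)N[C@H]3CN(S(=O)(=O)c4ccccc4)C[C@@H]3C(=O)NCCN(C)C)cc2c1` reads 2.1 and its mirror image compound 3 `Cc1ccc2[nH]c(C(=O)N[C@@H]3CN(S(=O)(=O)c4ccccc4)C[C@H]3C(=O)NCCN(C)C)cc2c1` reads 2.1 too, which places the pair level at the top of the three numbers. Compound 2 `Cc1ccc2[nH]c(C(=O)N[C@H]3CN(S(=O)(=O)c4cnccn4)C[C@@H]3C(=O)NCCN(C)C)cc2c1` lies lowest at 1 in the series. Compound 4 `Cc1ccc2[nH]c(C(=O)N[C@H]3CN(S(=O)(=O)c4ccccc4)C[C@@H]3C(=O)NC[C@H]3CCCN3)cc2c1` is still unmeasured and carries this difference from compound 1 pyrrolidin-2-yl in place of (dimethylamino)methyl on a saturated chain carbon bound to an amide-type nitrogen in which pyrrolidin-2-yl stands in place of (dimethylamino)methyl on a saturated chain carbon bound to an amide-type nitrogen. Two measured steps are available. Pyrazin-2-yl in place of phenyl on a sulfonyl sulfur gave a number 1.10 log units lower from compound 1 to compound 2 (beyond the scatter) and full inversion gave no change at the digits printed from compound 1 to compound 3 (within the scatter) in keeping with the fact that compounds 1 and 3 differ only in the configuration as drawn here. Neither step touches the amide side chain, so neither sets a size for this change, and the estimate rests on the structural change alone. A modest fall is expected, estimated as a number 0.40 log units lower from compound 1 to compound 4 (beyond the scatter) overall. Compound 4 is therefore expected at 1.7 with a range from 1.2 to 2.2 on this estimate.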

Compound 4, distribution coefficient: 1
Estimate against measurement, compound 4: 0.70 log units above, and the stated range ends above it.
By their numbers in this assay, from the lowest: compounds 2 and 4 (each within the scatter of the next); then compounds 1 and 3 (each within the scatter of the next).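

The side chain on the amide nitrogen proved to be a position that the read-out follows closely: in this assay, exchanging (dimethylamino)methyl for pyrrolidin-2-yl gave a number 1.10 log units lower from compound 1 to compound 4 (beyond the scatter) on a saturated chain carbon bound to an amide-type nitrogen. This change at the far end of the amide side chain was as large as the change on the sulfonyl sulfur, which gave a number 1.10 log units lower from compound 1 to compound 2 (beyond the scatter) in the same assay. The compounds shown do not separate the ring that enters from the hydrogen-bond donor that enters with it, and a 2-(methylamino)ethyl chain on the amide nitrogen would bear on that question. Also open, going by these compounds, are the opposite configuration of the pyrrolidin-2-yl stereocentre and the pairing of pyrrolidin-2-yl with pyrazin-2-yl on the sulfonyl sulfur. The only fact on record concerns the mirror-image pair of compound 1 and compound 3 and does not bear on this step.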